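This account rests on a few compounds, and the source may have more. Where it says the series, first, only, none or still open, it means among the compounds named here.

In a functional assay on ACHN cells (Homo sapiens) for inhibition, read by sulforhodamine B assay, with a stated time of 48 h (on this read-out higher numbers stand for weaker inhibition of growth and lower numbers for stronger inhibition of growth), compound 2 `O=C(Cc1csc2nc(-c3ccc(Br)cc3)cn12)N/N=C/c1ccc(O)cc1` gives 14800 nM, the highest of the two numbers recorded so far. Its nearest neighbour is compound 1 `O=C(Cc1csc2nc(-c3ccc(Br)cc3)cn12)N/N=C/c1ccccc1O`, which in this assay gives 1580 nM. For the measured compounds named here, the single measured step, a 9.4-fold higher number from compound 1 to compound 2 (0.97 log units; beyond the scatter), accompanied 4-hydroxyphenyl in place of 2-hydroxyphenyl on a carbon with a double bond to nitrogen.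

Compound 3 `O=C(Cc1csc2nc(-c3ccc(Br)cc3)cn12)N/N=C/c1ccc(Cl)cc1Cl` differs from compound 2 as follows: 2,4-dichlorophenyl in place of 4-hydroxyphenyl on a carbon with a double bond to nitrogen. Going by the values given here, no measured step bears directly on this change, since the one step recorded concerns only where a hydroxyl sits, not its replacement by chlorines; the direction of the step is therefore open, and the expectation leans on compound 2 and compound 1 bracketing the known range. Compound 3 is estimated to give 5000 nM in this assay, with a range from 1000 nM to 25000 nM. The expected step is a 3.0-fold lower number from compound 2 to compound 3 (0.47 log units; beyond the scatter).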

Compound 3, concentration for 50% growth inhibition: 22400 nM
For compound 3 the middle estimate is 4.5-fold (0.65 log units) below the measured one; low and high end bracket the measured number.
By their numbers in this assay, from the lowest: compound 1; then compounds 2 and 3 (each within the scatter of the next).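

In this assay, 2,4-dichlorophenyl in place of 4-hydroxyphenyl on a carbon with a double bond to nitrogen gives a 1.5-fold higher number from compound 2 to compound 3 (0.18 log units; within the scatter), so at this position a group with 0 hydrogen-bond donors cannot be told apart from one with 1 hydrogen-bond donor. The same group in place of 2-hydroxyphenyl gives a 14-fold higher number from compound 1 to compound 3 (1.15 log units; beyond the scatter), which leaves compound 1 as the only one of the three set apart from the others. No measurement on hand accounts for these numbers.

The compounds shown leave open whether the separation of compound 1 depends on the hydroxyl itself, and whether an amine or a methoxy group in place of that hydroxyl would keep it. They also leave open how a phenyl carrying a single chlorine would read in this series.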